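Notes on a bromophenol pyrazoline series in cytotoxicity

The source may hold more compounds than are shown below. What is called first, only, known or untested is meant among the compounds shown, and "the series" means these compounds.

The series is read in a functional assay on HepG2 cells (Homo sapiens) for cytotoxicity, read by MTT assay, with a stated time of 48 h; on this read-out higher numbers stand for weaker inhibition and lower numbers for stronger inhibition. Compound 1 `CC1=NN(C(=O)CCl)C(c2cc(Br)ccc2O)C1` gives 16300 nM in this assay, a weak value. Compound 2 `CC1=NN(C(=O)COc2ccc(Cl)cc2)C(c2cc(Br)ccc2O)C1` carries 4-chlorophenoxy on a saturated chain carbon bound to a carbonyl carbon; in this assay compound 2 is recorded as "not active" (no number reported), and no number is reported for it. Compound 2 therefore has no place on the scale beyond the absence of measurable inhibition within the tested range, and nothing can be said of its distance from compound 1.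

Compound 3 `C=CCN(CC=C)CC(=O)N1N=C(C)CC1c1cc(Br)ccc1O` differs from compound 2 in one place: diallylamino in place of 4-chlorophenoxy on a saturated chain carbon bound to a carbonyl carbon. Going by the values given here, no measured step covers this change, so its size is not known from the series. With compound 2 showing no activity and compound 1 at 16300 nM, the expectation for compound 3 in this assay is a value in the same weak region, with no move beyond the scatter in either direction foreseen. Compound 3 is estimated at 30000 nM, in the range 10000 nM to 100000 nM.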

Compound 3, half-maximal inhibitory concentration: 7870 nM
Beside the measured number, compound 3's estimate is 3.8-fold (0.58 log units) above it, and the stated range ends above it.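

The chain carbon bound to the carbonyl now has a readable comparison: in this assay, diallylamino in place of chloro gives a 2.1-fold lower number from compound 1 to compound 3 (0.32 log units; beyond the scatter), a modest gain that places a nitrogen-linked group at this position ahead of the chloro compound. Compound 2, with 4-chlorophenoxy at the same place, has no number, whereas compound 3 gives 7870 nM in this assay, so the change from 4-chlorophenoxy to diallylamino separates a compound recorded as not active from one with a measured value, though the size of that step cannot be read. Nothing at hand bears on why the number moves at this position.

The compounds shown leave open whether the two double bonds of diallylamino matter to this result, which diethylamino at the same place would test directly. From the compounds shown here alone, they also leave open whether a ring-bound amine such as morpholine, or a carboxylic acid on the same chain carbon, would carry the number further in either direction, so the reach of this single modest step remains unknown.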